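Swapping an ethyl for a cyclobutylcarbonyl on the ring nitrogen

A few compounds are considered here, and "the series" means these few. Any claim that something is new, unique, unknown or untested is made for them only; others in the source may bear on it.

Three compounds sharing a fused thiazole core with an alkyne-linked phenyl ring have been measured in an assay on HEK293 cells for negative allosteric modulation of metabotropic glutamate receptor 5 (Homo sapiens), read by FLIPR, with a stated time of 1 h; on this read-out lower numbers stand for stronger inhibition and higher numbers for weaker inhibition. Compound 1 `O=C1NCCc2nc(C#Cc3cccc(F)c3)sc21` gives only a limit of the assay, > 10000 nM, in this assay. Compound 2 `O=C1NCCc2nc(C#Cc3ccccc3F)sc21` likewise gives only a limit, > 10000 nM, in this assay. Among the measured compounds shown here, compound 3 `CCN1CCc2nc(C#Cc3ccccc3)sc2C1` is the one compound with a real number, 1200 nM in this assay, and so stands alone as the only measurable value among the three; two of the three values sit at the limit of > 10000 nM in this assay, at which 2 of the 3 values shown sit.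

Compound 4 `O=C(C1CCC1)N1CCc2nc(C#Cc3ccccc3)sc2C1` differs from compound 3 in one place: cyclobutylcarbonyl in place of ethyl on an amine nitrogen in a ring.

For the measured compounds named here, no step between two measured compounds is available here, so the direction and size of this change can only be anticipated. With compound 3 at 1200 nM as the single anchor, a moderate gain in potency, well beyond the usual scatter, is expected for compound 4, giving an estimated step of a 3.0-fold lower number from compound 3 to compound 4 (0.48 log units; beyond the scatter). Compound 4 is therefore expected to reach about 400 nM in this assay, within a range from 80 nM to 2500 nM.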

Compound 4, half-maximal inhibitory concentration: 370 nM
Compound 4: middle estimate off by 1.1-fold (0.03 log units), on the high side; the range from low to high includes it.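

Among the compounds shown here, this is the first measured step, and it falls on the amine nitrogen in the ring: in this assay, cyclobutylcarbonyl in place of ethyl gives a 3.2-fold lower number from compound 3 to compound 4 (0.51 log units; beyond the scatter). So this nitrogen can carry a much larger group, one with a carbonyl and a four-membered ring, and the number still falls rather than rises, which shows that a simple ethyl is not needed there for inhibition. Nothing shown explains why the number falls.

From the compounds shown here alone, the change brings in the carbonyl and the four-membered ring together, so their separate contributions remain open. A cyclobutylmethyl group would keep the ring without the carbonyl, and an acetyl group would keep the carbonyl without the ring, so either could help show which part goes with the lower number.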